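A Larger Group on the Chain Carbon of Compound 2

This account rests on a few compounds, and the source may have more. Where it says the series, first, only, none or still open, it means among the compounds named here.

Going by the values given here, in a functional assay on MCF7 cells (Homo sapiens) for antiproliferative activity, read by CellTiter-Glo, with a stated time of 5 days (a higher number here means a weaker inhibitor, a lower number a stronger inhibitor), three compounds have numbers so far. Compound 1 `O=C(O)/C=C/c1ccc(/C(=C(\c2ccc(F)cc2Cl)C2CCC2)c2ccc3scnc3c2)cc1` gives 3 nM, compound 2 `O=C(O)/C=C/c1ccc(/C(=C(\c2ccc(F)cc2Cl)C2CCC2)c2ccc3nccn3c2)cc1` gives 4.4 nM and compound 3 `O=C(O)/C=C/c1ccc(/C(=C(\c2ccc(C(F)(F)F)cc2Cl)C2CCC2)c2ccc3nccn3c2)cc1` gives 5.1 nM. Compound 2 lies within the scatter of both compounds it connects to, so these numbers give it no firm rank.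

Compound 4 `O=C(O)/C=C/c1ccc(/C(=C(\c2ccc(F)cc2Cl)C2CCC2)c2ccc(-c3cncs3)cc2)cc1` has not yet been measured in this assay. It carries 4-(1,3-thiazol-5-yl)phenyl where compound 2 carries a different group: a group of 11 heavy atoms (9 carbon, 1 nitrogen, 1 sulfur; one five-membered aromatic ring with 2 hetero atoms, one six-membered aromatic ring of carbon only) in place of a group of 9 heavy atoms (7 carbon, 2 nitrogen; one five-membered aromatic ring with 2 hetero atoms, one six-membered aromatic ring with 1 hetero atom), on a double-bonded chain carbon bound to an aromatic carbon and a double-bonded chain carbon.

Among the compounds with values here, the nearest precedent for an expectation is a 1.5-fold higher number from compound 1 to compound 2 (0.17 log units; within the scatter), an exchange at the same place. A second measured step, a 1.2-fold higher number from compound 2 to compound 3 (0.06 log units; within the scatter), concerns a different change, trifluoromethyl in place of fluoro on an aromatic carbon, and gives only indirect guidance. Neither step tests the group that enters here, so the data offer no direct measure of this exchange, and the uncertainty stays wide. No step beyond the scatter is expected in this assay, and the estimated step is a 1.6-fold higher number from compound 2 to compound 4 (0.20 log units; within the scatter). For compound 4 the estimated value is 7 nM, with an expected range of 2.5 nM to 20 nM.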

Compound 4, half-maximal inhibitory concentration: 4.2 nM
Compound 4: the middle estimate sits 1.7-fold (0.22 log units) above what was measured, and the stated range covers the measured number.
By their numbers in this assay, from the lowest: compounds 1, 4, 2 and 3 (each within the scatter of the next).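

In this assay, the double-bonded chain carbon accepts the larger 4-(1,3-thiazol-5-yl)phenyl, a group of 11 heavy atoms with a six-membered aromatic ring of carbon only, with no step beyond the scatter (a 1.0-fold lower number from compound 2 to compound 4 (0.02 log units; within the scatter)). Going by these compounds alone, measured against 1,3-benzothiazol-5-yl, the reading is the same (a 1.4-fold higher number from compound 1 to compound 4 (0.15 log units; within the scatter)), so the three groups at this place, which the earlier compounds had sampled only at 9 heavy atoms, all stand within the scatter of one another and cannot be ranked. No measurement on hand accounts for this agreement in the numbers.

The compounds shown carry only groups with two aromatic rings at this place, so it remains open whether a group such as a simple amine or a carboxylic acid on the same chain carbon would also stay within the scatter, or whether a step beyond it would finally appear. On these data alone, it is also open whether trifluoromethyl in place of fluoro on the aromatic carbon would again stay within the scatter when 4-(1,3-thiazol-5-yl)phenyl is present.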